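The source may hold more compounds than are shown below. What is called first, only, known or untested is meant among the compounds shown, and "the series" means these compounds.

Measured so far in a functional assay on UACC-257 cells (Homo sapiens) for inhibition, read by sulforhodamine B assay, with a stated time of 48 h; a lower number here means that less compound is tolerated, a higher number that more compound is tolerated:
compound 1, `COc1cc(-c2nn(-c3cccc(NC(=O)c4cccc(C(F)(F)F)c4)c3)cc2-c2ccncc2)ccc1Cl` — > 50000 nM
compound 2, `COc1cc(-c2nn(-c3cccc(NC(=O)c4ccc(Cl)c(C(F)(F)F)c4)c3)cc2-c2ccncc2)ccc1Cl` — > 32500 nM

For compound 2 the value > 32500 nM is a limit of the assay, not a number. For compound 1 the value > 50000 nM is likewise a limit. Among the measured compounds shown here, compound 2 thus stands only at a limit, and the one other value shown is a limit as well. The step that the two limits leave unreadable from compound 1 to compound 2 cannot be read between the limit of > 32500 nM in this assay, at which 1 of the 2 values shown sits, and (the limit of > 50000 nM in this assay, at which 1 of the 2 values shown sits).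

Compound 3, `COc1cc(-c2nn(-c3cccc(NC(=O)Nc4ccc(Cl)c(C(F)(F)F)c4)c3)cc2-c2ccncc2)ccc1Cl`, differs from compound 2 by (4-chloro-3-(trifluoromethyl)phenyl)amino in place of 4-chloro-3-(trifluoromethyl)phenyl on a carbonyl carbon. No measured step bears on this change, and the single step shown is unreadable, so no direction beyond the scatter is expected in this assay. Compound 3 is expected at 40000 nM (range 15000 nM to 100000 nM), an expected step that the limit leaves unreadable from compound 2 to compound 3, most likely reported again as a limit.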

Compound 3, concentration lethal to 50% of the cells: 29200 nM
The estimate for compound 3 lay 1.4-fold (0.14 log units) above the measured number; the range from low to high includes it.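

In this assay, the (4-chloro-3-(trifluoromethyl)phenyl)amino group on a carbonyl carbon gives the only number among the compounds shown, with an at least 1.1-fold lower number from compound 2 to compound 3 (0.04 log units; that floor lies within the scatter) and an at least 1.7-fold lower number from compound 1 to compound 3 (0.23 log units; that floor lies within the scatter), so neither step establishes a change beyond the scatter. Compound 2 stands at a limit, which leaves its step a floor only: the limit of > 32500 nM in this assay, at which 1 of the 3 values shown sits. Compound 1 likewise stands at a limit: the limit of > 50000 nM in this assay, at which 1 of the 3 values shown sits.

Still open, going by these compounds, is how a carboxylic acid or a longer chain on that carbonyl carbon, in place of the (4-chloro-3-(trifluoromethyl)phenyl)amino group, would read in this assay.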